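The compounds below may be only part of what the source reports. "The series", "measured", "known", "first", "only" and "open" are said of these compounds alone.

Measured in a functional assay on MCF7 cells (Homo sapiens) for inhibition, read by sulforhodamine B assay, with a stated time of 48 h; on this read-out higher numbers stand for weaker inhibition of growth and lower numbers for stronger inhibition of growth:
Compound 1 `O=C(CCl)NC(=O)Nc1ccc(-c2ccccc2)cc1` gives 3900 nM
Compound 2 `O=C(CCl)NC(=O)Nc1ccc(OC2CCCCCC2)cc1` gives 3600 nM

The two values lie within the scatter of each other, so compound 2 does not stand apart from compound 1 on these numbers. Compound 3 `O=C(CCl)NC(=O)Nc1ccc(Oc2ccccc2)cc1` differs from compound 2 by phenyl in place of cycloheptyl on an oxygen on an aromatic ring. Among the measured compounds shown here, no measured step isolates this change. Compound 1 at 3900 nM and compound 2 at 3600 nM carry different groups yet stay within the scatter, so no step beyond the scatter is expected in this assay. The expected change is a 1.2-fold lower number from compound 2 to compound 3 (0.08 log units; within the scatter) and lies within the scatter. For compound 3 the estimated value is 3000 nM with an expected range from 1200 nM to 8000 nM in this read-out.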

Compound 3, concentration for 50% growth inhibition: 4200 nM
For compound 3 the middle estimate is 1.4-fold (0.15 log units) below the measured one; low and high end bracket the measured number.
By their numbers in this assay, from the lowest: compounds 2, 1 and 3 (each within the scatter of the next).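

In this assay the change of cycloheptyl to phenyl on the oxygen gives a 1.2-fold higher number from compound 2 to compound 3 (0.07 log units; within the scatter) and stays within the scatter, so a seven-membered non-aromatic ring of carbon only and a six-membered aromatic ring of carbon only are not told apart here. Phenoxy in place of phenyl on an aromatic carbon gives a 1.1-fold higher number from compound 1 to compound 3 (0.03 log units; within the scatter) and also stays within the scatter, so adding the oxygen shows no separate effect. No measurement at hand bears on this result.

The compounds shown leave open whether an amine or a carboxylic acid in place of the phenyl on the oxygen would move the number beyond the scatter. From the compounds shown here alone, a small methyl on that oxygen remains equally open.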